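The compounds below may be only part of what the source reports. "The series", "measured", "known", "first", "only" and "open" are said of these compounds alone.

Of the compounds shown here, three built on one shared core have been tested in an assay on cells for inhibition of HSP60/HSP10 (Homo sapiens), with a stated time of 60 min; a higher number here means a weaker inhibitor, a lower number a stronger inhibitor. Compound 1 `Cc1ccccc1S(=O)(=O)Nc1ccc2oc(-c3ccccc3)nc2c1` gives > 100000 nM, which is a limit of the assay rather than a number. Compound 2 `O=S(=O)(Nc1ccc2oc(-c3ccccc3)nc2c1)c1ccccc1Cl` likewise gives > 100000 nM, again a limit. For the measured compounds named here, compound 3 `O=S(=O)(Nc1ccc2oc(-c3ccccc3)nc2c1)c1ccc(O)cc1` gives 88000 nM, the only real number among the three; the other two values sit at the limit of > 100000 nM in this assay, at which 2 of the 3 values shown sit. The step from compound 1 to compound 2 is a step that the two limits leave unreadable from compound 1 to compound 2. The steps of an at least 1.1-fold lower number from compound 1 to compound 3 (0.05 log units; that floor lies within the scatter) and an at least 1.1-fold lower number from compound 2 to compound 3 (0.05 log units; that floor lies within the scatter) show only that the move to 4-hydroxyphenyl on the sulfonyl sulfur carried the value into the range the assay can report, and both floors lie within the scatter.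

Compound 4 `C=Cc1ccc(S(=O)(=O)Nc2ccc3oc(-c4ccccc4)nc3c2)cc1` differs from compound 3 in one place: vinyl in place of hydroxy on an aromatic carbon. Going by the values given here, none of the measured steps exchanges a hydroxy for a vinyl, so none bears on this change directly; together they show only how weak the whole series is. The expected step of a 1.4-fold higher number from compound 3 to compound 4 (0.13 log units; within the scatter) is therefore set close to nothing, with wide uncertainty on either side. Compound 4 is estimated at 120000 nM, between 40000 nM and 400000 nM, with a real chance that the assay returns only a limit.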

Compound 4, half-maximal inhibitory concentration: > 100000 nM
Compound 4: a limit, no number; the forecaster's own chance of this, stated with the estimate: 60%; the middle value does not contradict the limit.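

In this assay compound 4 gives > 100000 nM, a limit of the assay and not a number. At this place, on an aromatic carbon para to a large group, the exchange of hydroxy for vinyl gives an at least 1.1-fold higher number from compound 3 to compound 4 (0.05 log units; that floor lies within the scatter), so the data show no change beyond the scatter, while the true size of the step stays hidden behind the limit; the steps to compound 4 from compound 1 and compound 2 cannot be read. For the compounds shown here, the new result does show that a group at this place does not by itself yield a reportable value, as compound 4 carries vinyl there and still reaches only the limit, so compound 3 remains the only compound here with a real number: the limit of > 100000 nM in this assay, at which 3 of the 4 values shown sit.

As far as these compounds go, how far compound 4 lies past the limit remains unknown, and so does whether the hydroxy group of compound 3 matters at all, given that the step stays within the scatter. Also open, from the compounds shown here alone, is whether an amine, a carboxylic acid or a methoxy group at this same place would give a number clearly stronger than that of compound 3.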